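Methyl for trifluoromethyl: notes on compounds 1 to 4

The source may hold more compounds than are shown below. What is called first, only, known or untested is meant among the compounds shown, and "the series" means these compounds.

Values in a functional assay on Huh-7 cells (Homo sapiens) for inhibition, read by sulforhodamine B assay, with a stated time of 72 h; on this read-out lower numbers stand for stronger inhibition and higher numbers for weaker inhibition:

- compound 1, `Cc1ccc(C2=Nn3c(nnc3C(C)c3ccc(CC(C)C)cc3)SC2)cc1`: 5000 nM
- compound 2, `COc1ccc2cc(C(C)c3nnc4n3N=C(c3ccc(C(F)(F)F)cc3)CS4)ccc2c1`: 14800 nM
- compound 3, `CC(C)Cc1ccc(C(C)c2nnc3n2N=C(c2ccc(C(F)(F)F)cc2)CS3)cc1`: 8400 nM

Compound 2 and compound 3 carry the same 4-(trifluoromethyl)phenyl group but differ in their cores; how the two cores differ is not broken down here. On this read-out compound 2 sits within the scatter of compound 3 and beyond the scatter of compound 1, so no order among the three is claimed beyond that.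

One change has been measured once: compound 3 to compound 1, (methyl in place of trifluoromethyl on an aromatic carbon). It gave a 1.7-fold lower number from compound 3 to compound 1 (0.23 log units; within the scatter), a step that does not rise above the scatter of repeated measurements.

Compound 4, `COc1ccc2cc(C(C)c3nnc4n3N=C(c3ccc(C)cc3)CS4)ccc2c1`, is not yet measured. It comes from compound 2 by methyl in place of trifluoromethyl on an aromatic carbon. The place of the change reads the same in both pairs, so this is the same change made on the core of compound 2 rather than on the core of compound 3.

Within the data shown here, with only one prior instance of the change, the expectation for compound 4 rests on it alone. The expected step is a 1.7-fold lower number from compound 2 to compound 4 (0.23 log units; within the scatter), because the move from compound 3 to compound 1 gave a 1.7-fold lower number from compound 3 to compound 1 (0.23 log units; within the scatter). Since that step was within the scatter, a number near that of compound 2 would not contradict this expectation.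

In this assay compound 4 is estimated at 8700 nM, with a range from 4000 nM to 20000 nM.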

Compound 4, half-maximal inhibitory concentration: 8200 nM
Compound 4: the middle estimate sits 1.1-fold (0.03 log units) above what was measured; the range from low to high includes it.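

In this assay, methyl in place of trifluoromethyl on the core of compound 2 gave a 1.8-fold lower number from compound 2 to compound 4 (0.26 log units; within the scatter). Set beside the earlier instance, the change carries from one core to the other with a step of much the same size: the same change on two cores in this assay, a 1.7-fold lower number (0.23 log units; within the scatter) from compound 3 to compound 1 and a 1.8-fold lower number (0.26 log units; within the scatter) from compound 2 to compound 4, 1.1-fold (0.03 log units) apart, within the scatter of two such steps. Each step taken alone stays within the scatter and two cores make no rule for a third, so this agreement does not establish that methyl and trifluoromethyl truly differ on this read-out.

Only 4-(trifluoromethyl)phenyl and 4-methylphenyl appear at this place on the six-membered aromatic ring, which leaves open whether a chlorine atom, an amine, a carboxylic acid or a longer chain there would give a step beyond the scatter. Also open, as far as these compounds go, is whether the same small step would hold on a core other than those of compounds 1 and 2.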